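This account rests on a few compounds, and the source may have more. Where it says the series, first, only, none or still open, it means among the compounds named here.

Compound 1 `CCc1ccc(-c2nc3c(c(C)nn3-c3ccccc3)c(-c3ccccc3C)c2C#N)cc1`: 6000 nM
Compound 2 `CCc1ccc(-c2nc3c(c(C)nn3-c3ccccc3)c(-c3ccccc3C(F)(F)F)c2C#N)cc1`: 11000 nM
Compound 3 `CCc1ccc(-c2nc3c(c(C)nn3-c3ccccc3)c(-c3ccccc3)c2C#N)cc1`: 47000 nM

These numbers come from a physicochemical assay for solubility, read by spectrophotometry, in phosphate buffer, with a stated time of 18 h, at pH 7.4; on this read-out lower numbers stand for lower solubility and higher numbers for higher solubility. Compound 1 gives the lowest of the three; compound 2 is nearest, with a 1.8-fold higher number from compound 1 to compound 2 (0.26 log units; within the scatter), and compound 3 is furthest, with a 7.8-fold higher number from compound 1 to compound 3 (0.89 log units; beyond the scatter). Compound 4 `C#Cc1ccccc1-c1c(C#N)c(-c2ccc(CC)cc2)nc2c1c(C)nn2-c1ccccc1` has not been measured yet. It differs from compound 1 by ethynyl in place of methyl on an aromatic carbon. For the measured compounds named here, the steps that bear on this change are the two earlier replacements of methyl on an aromatic carbon, a 1.8-fold higher number from compound 1 to compound 2 (0.26 log units; within the scatter) and a 7.8-fold higher number from compound 1 to compound 3 (0.89 log units; beyond the scatter), which both gave numbers within the scatter or higher. A small rise, if any, is therefore expected: a 1.5-fold higher number from compound 1 to compound 4 (0.18 log units; within the scatter). Compound 4 is estimated at 9000 nM, with a range from 3000 nM to 30000 nM.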

Compound 4, solubility: 46000 nM
Estimate against measurement, compound 4: 5.1-fold (0.71 log units) below, and the stated range ends below it.
By their numbers in this assay, from the lowest: compounds 1 and 2 (each within the scatter of the next); then compounds 4 and 3 (each within the scatter of the next).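

In this assay, ethynyl holds more heavy atoms than methyl, yet the change gives a 7.7-fold higher number from compound 1 to compound 4 (0.88 log units; beyond the scatter) and so does not keep the low number of compound 1. The same position also separates ethynyl from trifluoromethyl, with a 4.2-fold higher number from compound 2 to compound 4 (0.62 log units; beyond the scatter) here, while a 1.0-fold lower number from compound 3 to compound 4 (0.01 log units; within the scatter) leaves ethynyl level with plain hydrogen. No measurement at hand explains why these groups differ.

On these data alone, it remains open whether an amine, a methoxy group or a longer chain at this place would fall with compound 1 and compound 2 or with compound 3 and compound 4.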